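From phenyl to ethoxycarbonyl in a cytotoxic series

This account rests on a few compounds, and the source may have more. Where it says the series, first, only, none or still open, it means among the compounds named here.

Measured so far in a functional assay on Caco-2 cells (Homo sapiens) for cytotoxicity, read by MTT assay, with a stated time of 48 h; a higher number here means a weaker inhibitor, a lower number a stronger inhibitor:
compound 1 `C[n+]1cccc(OP(=O)([O-])OC[C@H]2O[C@@H](n3cc(F)c(=O)[nH]c3=O)C[C@@H]2OC(=O)c2ccccc2)c1` gives 1380 nM
compound 2 `CCCCCCCCCC[n+]1cccc(OP(=O)([O-])OC[C@H]2O[C@@H](n3cc(F)c(=O)[nH]c3=O)C[C@@H]2OC(=O)c2ccccc2)c1` gives 12900 nM
compound 3 `O=C(O[C@H]1C[C@H](n2cc(F)c(=O)[nH]c2=O)O[C@@H]1COP(=O)([O-])Oc1ccc[n+](Cc2ccccc2)c1)c1ccccc1` gives 430 nM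

Compound 3 stands lowest of the three, with both of its steps beyond the scatter. Compound 4 `CCOC(=O)C[n+]1cccc(OP(=O)([O-])OC[C@H]2O[C@@H](n3cc(F)c(=O)[nH]c3=O)C[C@@H]2OC(=O)c2ccccc2)c1` carries ethoxycarbonyl in place of phenyl on a saturated chain carbon bound to an aromatic nitrogen, a change counted as ethoxycarbonyl in place of phenyl on a saturated chain carbon bound to an aromatic nitrogen in full. Two measured steps at this place bear on it: a 3.2-fold lower number from compound 1 to compound 3 (0.51 log units; beyond the scatter) is modest and a 30-fold lower number from compound 2 to compound 3 (1.48 log units; beyond the scatter) is large. Among the compounds with values here, no measured compound carries ethoxycarbonyl, so the direction is uncertain, but with compound 3 at 430 nM as the lowest so far, a modest step to a higher number is expected in this assay here. The estimate means a 2.6-fold higher number from compound 3 to compound 4 (0.41 log units; beyond the scatter) as the expected step. For compound 4 the estimated value is 1100 nM within an expected range of 250 nM to 5000 nM overall.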

Compound 4, half-maximal inhibitory concentration: 2620 nM
Estimate against measurement, compound 4: 2.4-fold (0.38 log units) below; the measured number falls inside the stated range.
By their numbers in this assay, from the lowest: compound 3; then compounds 1 and 4 (each within the scatter of the next); then compound 2.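

In this assay, ethoxycarbonyl on the saturated chain carbon bound to an aromatic nitrogen does not keep the standing of phenyl, with a 6.1-fold higher number from compound 3 to compound 4 (0.78 log units; beyond the scatter). It remains clear of nonyl, with a 4.9-fold lower number from compound 2 to compound 4 (0.69 log units; beyond the scatter), but is not separated from hydrogen, with a 1.9-fold higher number from compound 1 to compound 4 (0.28 log units; within the scatter). Of the three groups compared with hydrogen at this place, only phenyl and nonyl now move the number beyond the scatter, and they move it in opposite directions.

From the compounds shown here alone, whether a carboxylic acid in place of ethoxycarbonyl, or an amine on this chain, would stand nearer compound 3 or compound 2 remains open. Nothing shown here accounts for these differences.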